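The compounds below may be only part of what the source reports. "The series", "measured", "known", "first", "only" and "open" are said of these compounds alone.

Among the measured compounds shown here, in a functional assay on MGC-803 cells (Homo sapiens) for inhibition, read by MTT assay, with a stated time of 48 h (a higher number here means a weaker inhibitor, a lower number a stronger inhibitor), compound 3 `C/C=C/C(=O)N(Cc1ccc(OC)c(O)c1)c1cc(OC)c(OC)c(OC)c1` gives 27 nM, the lowest of the three numbers measured so far. Compound 1 `C/C=C/C(=O)N(Cc1ccc(OC)c(N)c1)c1cc(OC)c(OC)c(OC)c1` gives 150 nM, and compound 2 `COc1ccc(CNc2cc(OC)c(OC)c(OC)c2)cc1F` gives 39700 nM. The next compound to be measured is compound 4 `C/C=C/C(=O)N(Cc1ccc(OC)c(F)c1)c1cc(OC)c(OC)c(OC)c1`, which has fluoro in place of hydroxy on an aromatic carbon, so that 3-hydroxy-4-methoxyphenyl becomes 3-fluoro-4-methoxyphenyl: fluoro in place of hydroxy on an aromatic carbon. For the measured compounds named here, only one measured step changes the group on this same carbon: hydroxy in place of amino gave a 5.6-fold lower number from compound 1 to compound 3 (0.74 log units; beyond the scatter), a modest step beyond the scatter. Compound 2 differs from compound 3 in more than one place, so it offers no clean comparison. In the one clean case, the compound with hydroxy has the lower number, so removing hydroxy here is expected to give a modest step toward a higher number in this assay. The expected change is a 5.6-fold higher number from compound 3 to compound 4 (0.74 log units; beyond the scatter). The estimate for compound 4 is 150 nM, with an expected range of 40 nM to 800 nM.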

Compound 4, half-maximal inhibitory concentration: 1650 nM
Estimate against measurement, compound 4: 11-fold (1.04 log units) below; the measured number lies above the stated range.
By their numbers in this assay, from the lowest: compound 3; then compound 1; then compound 4; then compound 2.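

In this assay, this carbon proves far more sensitive to the choice of group than the first swap suggested: fluoro in place of hydroxy gives a 61-fold higher number from compound 3 to compound 4 (1.79 log units; beyond the scatter), and fluoro in place of amino gives an 11-fold higher number from compound 1 to compound 4 (1.04 log units; beyond the scatter), so the order from lowest number to highest is hydroxy, amino, fluoro, with every step beyond the scatter. With fluoro on the ring in both compounds, the (prop-1-en-1-yl)carbonyl group on the nitrogen also counts for much, giving a 24-fold lower number from compound 2 to compound 4 (1.38 log units; beyond the scatter). No measurement shown explains why fluoro costs so much here.

Going by these compounds, whether chloro or a methyl group on this carbon would land nearer to hydroxy or to fluoro remains open. Also open, on these data alone, is whether the (prop-1-en-1-yl)carbonyl group matters as much when hydroxy stands on the ring.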